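This account rests on a few compounds, and the source may have more. Where it says the series, first, only, none or still open, it means among the compounds named here.

Measured in a functional assay on KG-1 cells (Homo sapiens) for cytotoxicity, read by luminescence and CellTiter-Glo, with a stated time of 3 days; on this read-out higher numbers stand for weaker inhibition and lower numbers for stronger inhibition:
compound 1 `O=C(Nc1ccc(C(F)(F)F)cc1)c1cc(Cl)ccc1O`: 740 nM
compound 2 `O=C(Nc1ccc(C(F)(F)F)cc1)c1cc(Cl)c(-c2ccccc2)cc1O`: 770 nM
compound 3 `O=C(Nc1ccc(C(F)(F)F)cc1)c1cc(Br)c(-c2ccccc2)cc1O`: 400 nM

Compound 2 , at 770 nM, sits within the scatter of both compound 1 and compound 3. The next compound, compound 4 `N#Cc1ccc(NC(=O)c2cc(Cl)c(-c3ccccc3)cc2O)cc1`, differs from compound 2 at one place: cyano in place of trifluoromethyl on an aromatic carbon.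

Among the measured compounds shown here, two measured steps bear on this only indirectly. Phenyl in place of hydrogen gave a 1.0-fold higher number from compound 1 to compound 2 (0.02 log units; within the scatter), and bromo in place of chloro gave a 1.9-fold lower number from compound 2 to compound 3 (0.28 log units; within the scatter). Both lie within the scatter, and both are at other places on the shared core. For the measured compounds named here, no measured compound alters the trifluoromethyl group, so the series offers no direct precedent, and these small steps do not show that this place is equally tolerant. A modest move towards weaker inhibition is expected in this assay, with wide uncertainty. The estimated step is a 1.6-fold higher number from compound 2 to compound 4 (0.19 log units; within the scatter). For compound 4 the estimated value is 1200 nM, with an expected range of 400 nM to 3500 nM.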

Compound 4, half-maximal inhibitory concentration: 480 nM
Compound 4: middle estimate off by 2.5-fold (0.40 log units), on the high side, within the range that was stated.
By their numbers in this assay, from the lowest: compounds 3, 4, 1 and 2 (each within the scatter of the next).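

In this assay, cyano in place of trifluoromethyl, the only change shown at this place, gives a 1.6-fold lower number from compound 2 to compound 4 (0.21 log units; within the scatter). Among the compounds shown here, the place, on an aromatic carbon para to a large group, therefore takes a swap from a group of four heavy atoms with no hydrogen-bond acceptor to one of two heavy atoms with one acceptor, and the step stays within the scatter; the earlier compounds all carry trifluoromethyl and could not show this. Nothing on hand accounts for this result.

Going by these compounds, with a single replacement at this place, it remains open whether the same tolerance holds for an amine, a carboxylic acid or a longer alkyl chain. Also open, on these data alone, is how cyano at this place behaves with bromo in place of chloro on the shared core.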